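From 3,4-dimethoxyphenyl to 3-fluorophenyl

A few compounds are considered here, and "the series" means these few. Any claim that something is new, unique, unknown or untested is made for them only; others in the source may bear on it.

Values so far in a functional assay on K562 cells (Homo sapiens) for antiproliferative activity, read by CCK-8 assay, with a stated time of 48 h (a higher number here means a weaker inhibitor, a lower number a stronger inhibitor), for three compounds:
Compound 1 (`COc1ccc(Nc2nc(Nc3cc(C)[nH]n3)cc(N3CCN(C)CC3)n2)cc1OC`) gives 462 nM
Compound 2 (`Cc1cc(Nc2cc(N3CCN(C)CC3)nc(Nc3ccc(Cl)c(F)c3)n2)n[nH]1`) gives 218 nM
Compound 3 (`Cc1cc(Nc2cc(N3CCN(C)CC3)nc(Nc3ccc(F)c(Cl)c3)n2)n[nH]1`) gives 95.2 nM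

Compound 1 has the highest number of the three, which makes it the weakest inhibitor so far. Compound 4 (`Cc1cc(Nc2cc(N3CCN(C)CC3)nc(Nc3cccc(F)c3)n2)n[nH]1`) has not yet been measured and differs from compound 1 in one place (3-fluorophenyl in place of 3,4-dimethoxyphenyl on a nitrogen on an aromatic ring): 3-fluorophenyl in place of 3,4-dimethoxyphenyl on a nitrogen on an aromatic ring. Two measured steps also replace the 3,4-dimethoxyphenyl, and both are modest (a 2.1-fold lower number from compound 1 to compound 2 (0.33 log units; beyond the scatter) and a 4.9-fold lower number from compound 1 to compound 3 (0.69 log units; beyond the scatter)). The two replacing groups also differ from each other (a 2.3-fold lower number from compound 2 to compound 3 (0.36 log units; beyond the scatter)). For the measured compounds named here, a modest step to a lower number is therefore expected in this assay, although no measured compound carries 3-fluorophenyl. An expected 2.3-fold lower number from compound 1 to compound 4 (0.36 log units; beyond the scatter) would fit these steps. The estimate for compound 4 is 200 nM (expected range 80 nM to 480 nM).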

Compound 4, half-maximal inhibitory concentration: 184 nM
The estimate for compound 4 lay 1.1-fold (0.04 log units) above the measured number; measured number inside the range.
By their numbers in this assay, from the lowest: compounds 3, 4 and 2 (each within the scatter of the next, the first and the last beyond it); then compound 1.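

In this assay, the 3-fluorophenyl alone is enough for a step beyond the scatter away from the 3,4-dimethoxyphenyl (a 2.5-fold lower number from compound 1 to compound 4 (0.40 log units; beyond the scatter)), so no chloro is needed for it. Hydrogen in place of chloro leaves no readable difference (a 1.2-fold lower number from compound 2 to compound 4 (0.07 log units; within the scatter)), and 3-fluorophenyl in place of 3-chloro-4-fluorophenyl is also unresolved (a 1.9-fold higher number from compound 3 to compound 4 (0.29 log units; within the scatter)). No measurement given here accounts for these steps. Still open, from the compounds shown here alone, is how a plain phenyl, a 3-methoxyphenyl or a 3-cyanophenyl would compare with the 3-fluorophenyl in this assay.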